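Changing the Amine Chain End of Compound 3

The source may hold more compounds than are shown below. What is called first, only, known or untested is meant among the compounds shown, and "the series" means these compounds.

In a functional assay on RS4-11 cells (Homo sapiens) for inhibition, read by CCK-8 assay, with a stated time of 72 h (on this read-out lower numbers stand for stronger inhibition and higher numbers for weaker inhibition), compound 3 `CN(C)CCCNc1ccc(S(=O)(=O)NC(=O)c2ccc(N3CCN(CC4=C(c5ccc(C(F)(F)F)cc5)CC(C)(C)CC4)CC3)cc2Oc2cnc3[nH]ccc3c2)cc1[N+](=O)[O-]` gives 3.9 nM, within the scatter of compound 1 `CC1(C)CCC(CN2CCN(c3ccc(C(=O)NS(=O)(=O)c4ccc(NCC5CCOCC5)c([N+](=O)[O-])c4)c(Oc4cnc5[nH]ccc5c4)c3)CC2)=C(c2ccc(C(F)(F)F)cc2)C1` at 6.2 nM, while compound 2 `CC1(C)CCC(CN2CCN(c3ccc(C(=O)NS(=O)(=O)c4ccc(NCC5CCOCC5)c([N+](=O)[O-])c4)c(Oc4cnc5[nH]ccc5c4)c3)CC2)=C(c2cccc(C(F)(F)F)c2)C1` gives 63 nM. Compound 4 `CN1CCC(CNc2ccc(S(=O)(=O)NC(=O)c3ccc(N4CCN(CC5=C(c6ccc(C(F)(F)F)cc6)CC(C)(C)CC5)CC4)cc3Oc3cnc4[nH]ccc4c3)cc2[N+](=O)[O-])C1` differs from compound 3 in one place: 1-methylpyrrolidin-3-yl in place of 2-(dimethylamino)ethyl on a saturated chain carbon bound to a nitrogen on an aromatic ring. One measured change falls at that place, a 1.6-fold lower number from compound 1 to compound 3 (0.20 log units; within the scatter), exchanging oxan-4-yl for 2-(dimethylamino)ethyl. The larger step, a 10-fold higher number from compound 1 to compound 2 (1.01 log units; beyond the scatter), exchanged 4-(trifluoromethyl)phenyl for 3-(trifluoromethyl)phenyl, a change that compound 4 does not share, so it offers no guide here. No step beyond the scatter is therefore expected in this assay. Compound 4 is estimated at 5 nM, with an expected range from 2 nM to 14 nM.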

Compound 4, half-maximal inhibitory concentration: 8.3 nM
Estimate against measurement, compound 4: 1.7-fold (0.22 log units) below; low and high end bracket the measured number.
By their numbers in this assay, from the lowest: compounds 3, 1 and 4 (each within the scatter of the next, the first and the last beyond it); then compound 2.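

In this assay, the 1-methylpyrrolidin-3-yl ring in place of the open 2-(dimethylamino)ethyl chain gives a 2.1-fold higher number from compound 3 to compound 4 (0.33 log units; beyond the scatter), a modest step and the only one at this position beyond the scatter. Against oxan-4-yl, the same ring gives a 1.3-fold higher number from compound 1 to compound 4 (0.13 log units; within the scatter), so compound 1 stays within the scatter of both amine-bearing compounds. No measured evidence bears on the reason for these differences. Going by these compounds, whether a primary amine, a carboxylic acid or a longer chain at this place would hold these numbers remains open. So does whether 3-(trifluoromethyl)phenyl would cost as much alongside the 1-methylpyrrolidin-3-yl ring.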